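The source may report more compounds than this note shows. Statements on the series, on what has been measured and on what is new or still open speak of the compounds shown alone.

Measured in a functional assay on HSC-4 cells (Homo sapiens) for cytotoxicity, with a stated time of 24 h; a lower number here means that less compound is tolerated, a higher number that more compound is tolerated:
- compound 1 `Cc1ccc(/C=C2\CCC/C(=C\c3ccccc3[N+](=O)[O-])C2=O)cc1` gives 40000 nM
- compound 2 `COc1cc(/C=C2\CCC/C(=C\c3ccccc3[N+](=O)[O-])C2=O)cc(OC)c1OC` gives 6500 nM
- compound 3 `O=C1/C(=C/c2ccc(F)cc2)CCC/C1=C\c1cccc([N+](=O)[O-])c1` gives 2500 nM

Compound 3 has the lowest number of the three, so the least of it is tolerated. Compound 2 and compound 1 both lie higher, each by more than the usual scatter of repeat measurements.

Compound 4 `Cc1ccc(/C=C2\CCC/C(=C\c3cccc([N+](=O)[O-])c3)C2=O)cc1` is compound 3 with a single change, methyl in place of fluoro on an aromatic carbon, para to a large group (methyl in place of fluoro on an aromatic carbon). Among the measured compounds shown here, no measured pair shows this swap alone, so its size can only be judged indirectly. For the measured compounds named here, the one measured compound with the methyl, compound 1, gives 40000 nM in this assay, but its nitro group sits elsewhere than in compound 4, so that number cannot be read as the effect of the methyl alone. A modest rise in this assay is therefore expected, towards more compound tolerated, and it may only just clear the scatter. The estimated change is a 2.0-fold higher number from compound 3 to compound 4 (0.30 log units; within the scatter). Compound 4 is estimated at 5000 nM, with an expected range from 1500 nM to 18000 nM.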

Compound 4, half-maximal cytotoxic concentration: 45000 nM
For compound 4 the middle estimate is 9.0-fold (0.95 log units) below the measured one; measured number above the stated range.
By their numbers in this assay, from the lowest: compound 3; then compound 2; then compounds 1 and 4 (each within the scatter of the next).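

In this assay, among the compounds shown here, the change from 4-fluorophenyl to 4-methylphenyl gives an 18-fold higher number from compound 3 to compound 4 (1.26 log units; beyond the scatter), which is the first clean reading of a single change in this set, and it shows that this one position strongly affects how much compound is tolerated. The exchange of one heavy atom for another is therefore far from a minor edit here, at least with the nitro group placed as it is in these two compounds. Compound 1 also carries the methyl but has its nitro group elsewhere; it gives 40000 nM and compound 4 gives 45000 nM, two values within the scatter of each other, so moving the nitro group shows no clear effect in this methyl pair. Nothing measured here accounts for the size of the step.

On these data alone, it remains open whether the swap from fluoro to methyl would have a similar size with the nitro group placed as in compound 1. As far as these compounds go, it is also open whether a chloro group, an ethyl group or a plain hydrogen at this position would give a number closer to that of compound 3 or to that of compound 4.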